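The source may hold more compounds than are shown below. What is called first, only, known or untested is meant among the compounds shown, and "the series" means these compounds.

Measured so far in a functional assay on COLO 205 cells (Homo sapiens) for inhibition, read by MTT assay, with a stated time of 24 h; a lower number here means a stronger inhibitor, a higher number a weaker inhibitor:
compound 1 `[O-]/[N+](=C\c1cn(-c2ccc(F)cc2)nn1)c1ccccc1` gives 10200 nM;
compound 2 `[O-]/[N+](=C\c1cn(-c2ccc(F)cc2)nn1)Cc1ccccc1` sits at a limit of the assay, > 100000 nM;
compound 3 `CC(C)(C)/[N+]([O-])=C/c1cn(-c2ccccc2)nn1` gives 15200 nM.

Compound 3 and compound 1 lie within the usual scatter of each other, so no order between them is claimed. For the measured compounds named here, the value of compound 2 is a limit and not a number; the limit of > 100000 nM in this assay, at which 1 of the 3 values shown sits, is the only limit among the values shown.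

Compound 4 `CC(C)(C)/[N+]([O-])=C/c1cn(-c2ccc(F)cc2)nn1` differs from compound 3 by fluoro in place of hydrogen on an aromatic carbon. Going by the values given here, no measured step bears on this change alone: the single step counted, an at least 9.8-fold higher number from compound 1 to compound 2 (0.99 log units; beyond the scatter), concerns a different group, and compound 1 and compound 3 differ in two places at once, so that pair yields no step. A change within the scatter is therefore expected, a 1.2-fold lower number from compound 3 to compound 4 (0.07 log units; within the scatter). Compound 4 is estimated at 13000 nM, between 4500 nM and 40000 nM.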

Compound 4, half-maximal inhibitory concentration: 58900 nM
Estimate against measurement, compound 4: 4.5-fold (0.66 log units) below, and the stated range ends below it.
By their numbers in this assay, from the lowest: compounds 1 and 3 (each within the scatter of the next); then compound 4. At a limit, above all of these: compound 2.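

In this assay, fluoro in place of hydrogen on an aromatic carbon, para to a large group, gives a 3.9-fold higher number from compound 3 to compound 4 (0.59 log units; beyond the scatter), the first step read at this position. With fluoro held constant, tert-butyl in place of phenyl on the double-bonded nitrogen gives a 5.8-fold higher number from compound 1 to compound 4 (0.76 log units; beyond the scatter). Tert-butyl in place of benzyl on the double-bonded nitrogen gives an at least 1.6-fold lower number from compound 2 to compound 4 (0.22 log units; that floor lies within the scatter). The value of compound 2 is a limit and not a number, so this step is only a floor: the limit of > 100000 nM in this assay, at which 1 of the 4 values shown sits.

As far as these compounds go, whether chloro, methoxy or an amine at this aromatic carbon would behave as fluoro does remains open. So does the size of the hydrogen-to-fluoro step with phenyl on the nitrogen.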